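This account rests on a few compounds, and the source may have more. Where it says the series, first, only, none or still open, it means among the compounds named here.

Series notes. Within the data shown here, in a functional assay on MDA-MB-231 cells (Homo sapiens) for cytotoxicity, read by MTT assay, with a stated time of 48 h (a lower number here means a stronger inhibitor, a higher number a weaker inhibitor), compound 1 `Cc1cn([C@@H]2SC[C@@](C)(O)[C@H]2O)c(=O)[nH]c1=O` gives 3000 nM, while compound 2 `Cc1cn([C@H]2SC[C@](C)(O)[C@@H]2O)c(=O)[nH]c1=O` gives 52000 nM, the highest of the two numbers so far. The step of a 17-fold higher number from compound 1 to compound 2 (1.24 log units; beyond the scatter) is large, and it rests only on (the fact that compounds 1 and 2 differ only in the configuration as drawn); no other change has been measured in this series.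

Compound 3 `C[C@]1(O)CS[C@H](n2ccc(=O)[nH]c2=O)[C@H]1O` differs from compound 2 by hydrogen in place of methyl on an aromatic carbon of a six-membered aromatic ring with 2 nitrogen, two atoms from the ring nitrogen. Compound 3 keeps the configuration of compound 2 at every stereocentre. Among the measured compounds shown here, none of the measured steps bears on removal of this methyl: the only measured step concerns configuration alone, not substitution of the aromatic ring. No direction can therefore be read from the data, and no step beyond the scatter is expected in this assay.

Compound 3 is estimated at 50000 nM, within 15000 nM to 160000 nM, which means an expected step of a 1.0-fold lower number from compound 2 to compound 3 (0.02 log units; within the scatter).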

Compound 3, half-maximal inhibitory concentration: 14000 nM
Beside the measured number, compound 3's estimate is 3.6-fold (0.55 log units) above it, outside the stated range (below it).
By their numbers in this assay, from the lowest: compound 1; then compound 3; then compound 2.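

In this assay, hydrogen in place of methyl on an aromatic carbon gives a 3.7-fold lower number from compound 2 to compound 3 (0.57 log units; beyond the scatter), so this position, two atoms from the ring nitrogen, responds to substitution, and the methyl is not required for the activity seen in this configuration. Among these compounds, this is the first measured change other than configuration, and it is modest beside a 17-fold higher number from compound 1 to compound 2 (1.24 log units; beyond the scatter). Nothing known about the series gives a cause for the step on removing the methyl.

As far as these compounds go, it remains open whether hydrogen in place of methyl gives a step of similar size and direction in the configuration of compound 1. Also open, from the compounds shown here alone, is how an ethyl group, a chlorine atom or a trifluoromethyl group on this aromatic carbon would compare with hydrogen and methyl.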